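Chloro in Place of Hydrogen on Compound 3

The source may hold more compounds than are shown below. What is called first, only, known or untested is meant among the compounds shown, and "the series" means these compounds.

In a functional assay on BT-549 cells (Homo sapiens) for cytotoxicity, read by MTT assay, with a stated time of 48 h (a lower number here means a stronger inhibitor, a higher number a weaker inhibitor), compound 3 `CC(C)n1c(/C=C2/C(=O)Nc3ccccc32)nc2ccccc21` gives 38900 nM and stands highest of the two numbered values, while compound 1 `CC(C)n1c(/C=C2/C(=O)Nc3ccc(Br)cc32)nc2ccccc21` gives 13700 nM in the same test. Compound 2 `CCn1c(/C=C2/C(=O)Nc3ccccc32)nc2ccccc21` gives > 50000 nM as a limit. Compound 4 `CC(C)n1c(/C=C2/C(=O)Nc3ccc(Cl)cc32)nc2ccccc21` carries chloro in place of hydrogen on an aromatic carbon. The step of an at least 1.2-fold lower number from compound 2 to compound 3 (0.10 log units; that floor lies within the scatter) concerns a saturated chain carbon and has a floor within the scatter, so it says little here. With a 2.8-fold higher number from compound 1 to compound 3 (0.45 log units; beyond the scatter) read in reverse, a modest step beyond the scatter, chloro is expected to lower the number by a similar or slightly smaller amount. The expected change is a 2.3-fold lower number from compound 3 to compound 4 (0.36 log units; beyond the scatter) by this estimate. Compound 4 is estimated at 17000 nM with 8000 nM and 35000 nM as the ends of the expected range.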

Compound 4, half-maximal inhibitory concentration: 35100 nM
Compound 4: middle estimate off by 2.1-fold (0.31 log units), on the low side; measured number above the stated range.
By their numbers in this assay, from the lowest: compound 1; then compounds 4 and 3 (each within the scatter of the next). At a limit, above all of these: compound 2.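

In this assay, chloro in place of hydrogen on this aromatic carbon gives a 1.1-fold lower number from compound 3 to compound 4 (0.04 log units; within the scatter), so this change does not separate the two compounds. Bromo at the same carbon stands apart from chloro, with a 2.6-fold higher number from compound 1 to compound 4 (0.41 log units; beyond the scatter), which shows that the earlier bromo step does not carry over to every halogen here. Nothing measured here explains why bromo and chloro differ. The compounds shown leave open whether iodo, methoxy or an amine at this carbon would follow chloro or bromo.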